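A few compounds are considered here, and "the series" means these few. Any claim that something is new, unique, unknown or untested is made for them only; others in the source may bear on it.

Measured so far:
compound 1, `Cc1cccc(Nc2nccc(-c3ccsc3)n2)c1`: 3800 nM
compound 2, `CC1CCN(c2cccc(Nc3nccc(-c4ccco4)n3)c2)CC1`: 5000 nM

Of the compounds shown here, two have been measured in a functional assay for inhibition, with Homo sapiens as the target; a lower number here means a stronger inhibitor, a higher number a weaker inhibitor. Compound 1 `Cc1cccc(Nc2nccc(-c3ccsc3)n2)c1` gives 3800 nM in this assay. Compound 2 `CC1CCN(c2cccc(Nc3nccc(-c4ccco4)n3)c2)CC1` gives 5000 nM in this assay. These two numbers lie within the usual scatter of each other, so neither compound can be set apart from the other on this evidence, and compound 2 stands close beside compound 1 rather than clearly apart from it.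

Compound 3 `Cc1cccc(Nc2nccc(-c3ccco3)n2)c1` has not yet been measured in this assay. It differs from compound 2 in a single place: methyl in place of 4-methylpiperidin-1-yl on an aromatic carbon. Within the data shown here, no step between measured compounds isolates this change; compound 1 carries the same methyl group as compound 3 but differs from it elsewhere, a pair for which no step is given. Since the two measured compounds sit together despite their different substituents, no change beyond the scatter is expected from compound 2 to compound 3 in this assay. The estimated step is a 1.3-fold lower number from compound 2 to compound 3 (0.10 log units; within the scatter). Compound 3 is expected to give about 4000 nM in this assay, with a range from 1500 nM to 12000 nM.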

Compound 3, half-maximal inhibitory concentration: 2100 nM
Compound 3: the middle estimate sits 1.9-fold (0.28 log units) above what was measured; low and high end bracket the measured number.
By their numbers in this assay, from the lowest: compounds 3, 1 and 2 (each within the scatter of the next, the first and the last beyond it).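

In this assay, among these compounds, methyl in place of 4-methylpiperidin-1-yl on an aromatic carbon, meta to a large group, gives a 2.4-fold lower number from compound 2 to compound 3 (0.38 log units; beyond the scatter) and so is the one step here that lies beyond the scatter, though it is modest and shows that this place tolerates the loss of the whole ring with no penalty in the number. Furan-2-yl in place of thiophen-3-yl gives a 1.8-fold lower number from compound 1 to compound 3 (0.26 log units; within the scatter) and stays within the scatter, so that exchange cannot be told apart from no change on this evidence. Nothing available here accounts for the step at the methyl position.

The compounds shown leave open whether the step depends on the ring of 4-methylpiperidin-1-yl or would also appear with an open-chain dimethylamino group, a morpholin-4-yl ring, or a small group such as methoxy or chlorine on the same carbon. They also leave open what a phenyl or pyridin-3-yl group would do in the place held by furan-2-yl and thiophen-3-yl, and whether the furan-2-yl and thiophen-3-yl exchange would behave alike with 4-methylpiperidin-1-yl present.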